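Larger Aromatic Ether Tested on a Weak Jurkat Inhibitor

The source may report more compounds than this note shows. Statements on the series, on what has been measured and on what is new or still open speak of the compounds shown alone.

Compound 1, `CC(C)[C@H](NC(=O)COc1cccc2ccccc12)C(=O)N[C@@H](CC(=O)O)C(=O)CSc1nnc(-c2ccccc2)o1`: 150000 nM
Compound 2, `CC(C)[C@H](NC(=O)COc1cccc2ccccc12)C(=O)N[C@@H](CC(=O)O)C(=O)COc1ccccn1`: > 200000 nM

In a functional assay on Jurkat cells (Homo sapiens) for inhibition (a higher number here means a weaker inhibitor, a lower number a stronger inhibitor), compound 1 gives 150000 nM. Compound 2 gives only a limit, > 200000 nM, so it sits at the limit of > 200000 nM in this assay, at which 1 of the 2 values shown sits. Going by the values given here, the single measured step at this place is an at least 1.3-fold higher number from compound 1 to compound 2 (0.12 log units; that floor lies within the scatter). Compound 3, `CC(C)[C@H](NC(=O)COc1cccc2ccccc12)C(=O)N[C@@H](CC(=O)O)C(=O)COc1cncc2ccccc12`, carries isoquinolin-4-yl in place of pyridin-2-yl on an oxygen on a saturated carbon. Among the compounds with values here, no measured step tests this change directly, and the one change at the same place ended at the limit. Compound 3 is therefore expected to stay near the limit, with a number no higher from compound 2 to compound 3 (the limit leaves the size open) expected to lie within the scatter. For compound 3 the estimate in this assay is 200000 nM, ranging from 80000 nM to 500000 nM.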

Compound 3, half-maximal inhibitory concentration: 166000 nM
Beside the measured number, compound 3's estimate is 1.2-fold (0.08 log units) above it; the range from low to high includes it.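

Compound 2 stands at a limit, not a number: the limit of > 200000 nM in this assay, at which 1 of the 3 values shown sits. In this assay, isoquinolin-4-yl in place of pyridin-2-yl on the oxygen gives an at least 1.2-fold lower number from compound 2 to compound 3 (0.08 log units; that floor lies within the scatter), so the larger ring system gives a measurable value, but the step's floor does not clear the scatter. Going by these compounds alone, replacing (5-phenyl-1,3,4-oxadiazol-2-yl)sulfanyl with (isoquinolin-4-yl)oxy gives a 1.1-fold higher number from compound 1 to compound 3 (0.04 log units; within the scatter), the one step at this place read between two actual numbers.

As far as these compounds go, the true size of the step from the limit stays open. So does whether an amine in place of the (isoquinolin-4-yl)oxy group would move the number beyond the scatter.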